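This account rests on a few compounds, and the source may have more. Where it says the series, first, only, none or still open, it means among the compounds named here.

Compound 1 `CN1CCN(C(=O)CCCOc2cc(C(=O)N3CCCCc4sccc43)ccc2NC(=O)c2ccccc2-c2ccccc2)CC1` carries a (4-methylpiperazin-1-yl)carbonyl group on a saturated chain that runs from an oxygen on an aromatic ring. In an assay on adrenal medulla for inhibition of Vasopressin V2 receptor (Rattus norvegicus), read by radioligand binding (on this read-out lower numbers stand for stronger inhibition and higher numbers for weaker inhibition), compound 1 gives 1 nM. Compound 2 `CN1CCCN(CCCOc2cc(C(=O)N3CCCCc4sccc43)ccc2NC(=O)c2ccccc2-c2ccccc2)CC1` replaces that group with 4-methyl-1,4-diazepan-1-yl, and in this assay compound 2 gives < 1 nM, which is a limit of the assay and not a number. On these data alone, compound 2 therefore stands at the limit of < 1 nM in this assay, at which 1 of the 2 values shown sits, so its exact potency remains open. The measured step of a number no higher from compound 1 to compound 2 (the limit leaves the size open) cannot be sized for the same reason.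

Compound 3 `CN1CCCN(C(=O)CCCOc2cc(C(=O)N3CCCCc4sccc43)ccc2NC(=O)c2ccccc2-c2ccccc2)CC1` differs from compound 2 by (4-methyl-1,4-diazepan-1-yl)carbonyl in place of 4-methyl-1,4-diazepan-1-yl on a saturated chain carbon, three bonds along the chain from an oxygen on an aromatic ring. Among the compounds with values here, no measured step adds a carbonyl to an otherwise unchanged chain, so the expectation rests on compound 1, which already carries such a carbonyl and gives 1 nM in this assay. For compound 2 only a limit is known. Compound 3 is therefore expected to sit close to compound 1, with the step of an at least 1.5-fold higher number from compound 2 to compound 3 (0.17 log units; that floor lies within the scatter) expected to be small and of open direction. The estimate for compound 3 is 1.5 nM, in a range from 0.4 nM to 6 nM.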

Compound 3, half-maximal inhibitory concentration: 3 nM
Compound 3: the middle estimate sits 2.0-fold (0.30 log units) below what was measured, within the range that was stated.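

In this assay, within the data shown here, this result isolates the carbonyl for the first time, since the step from compound 1 to compound 2 changed the ring and the carbonyl together. With 4-methyl-1,4-diazepan-1-yl kept in both compounds, adding the carbonyl on the saturated chain carbon gives an at least 3.0-fold higher number from compound 2 to compound 3 (0.47 log units; beyond the scatter), so at this position the carbonyl is not a neutral addition, and the printed size is only a floor because compound 2 stands at a limit: the limit of < 1 nM in this assay, at which 1 of the 3 values shown sits.

The ring can now be read on its own as well: with the carbonyl kept, 4-methyl-1,4-diazepan-1-yl in place of 4-methylpiperazin-1-yl on the carbonyl carbon gives a 3.0-fold higher number from compound 1 to compound 3 (0.48 log units; beyond the scatter), which shows that the ring on the carbonyl also counts in this assay.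

The compounds shown leave open how 4-methylpiperazin-1-yl would read placed directly on the chain without the carbonyl, which would show whether the carbonyl step holds for a second ring. They also leave open what a simple open-chain amine such as dimethylamino, or a longer chain between the oxygen and the ring, would do at this position.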